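Halogen swap on the thiourea aryl ring of compound 1

A few compounds are considered here, and "the series" means these few. Any claim that something is new, unique, unknown or untested is made for them only; others in the source may bear on it.

Measured so far:
compound 1, `NC(=O)c1c(NC(=O)c2ccccc2I)sc2c1CCN(C(=S)Nc1ccccc1Cl)C2`: 8560 nM in a functional assay on HL-60 cells (Homo sapiens) for antiproliferative activity, with a stated time of 24 h; on this read-out lower numbers stand for stronger inhibition and higher numbers for weaker inhibition
compound 2, `NC(=O)c1c(NC(=O)c2ccccc2C(F)(F)F)sc2c1CCN(C(=S)Nc1ccccc1Cl)C2`: 17600 nM in this assay

Compound 1 gives the lower of the two numbers in this assay; the nearest, compound 2, sits a 2.1-fold higher number from compound 1 to compound 2 (0.31 log units; beyond the scatter). Among the measured compounds shown here, that is the only step recorded so far, and it concerns the benzoyl ring, not the thiourea side. Compound 3, `NC(=O)c1c(NC(=O)c2ccccc2I)sc2c1CCN(C(=S)Nc1ccccc1Br)C2`, differs from compound 1 on that other side: bromo in place of chloro on an aromatic carbon. For the measured compounds named here, no measured step touches this position, so the expectation can rest only on the change itself, one halogen replaced by another of similar kind. For compound 3 the estimated step is a 1.1-fold lower number from compound 1 to compound 3 (0.03 log units; within the scatter), which is expected to stay within the scatter. The estimate for compound 3 in this assay is 8000 nM, range 3500 nM to 18000 nM.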

Compound 3, half-maximal inhibitory concentration: 18900 nM
Estimate against measurement, compound 3: 2.4-fold (0.37 log units) below, outside the stated range (above it).
By their numbers in this assay, from the lowest: compound 1; then compounds 2 and 3 (each within the scatter of the next).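

The position on the aromatic ring of the thiourea side responds in this assay: going from 2-chlorophenyl to 2-bromophenyl gives a 2.2-fold higher number from compound 1 to compound 3 (0.34 log units; beyond the scatter) with the rest of the molecule unchanged. An exchange of one halogen for another, ortho to a large group, is therefore enough to weaken the read-out beyond the scatter, and the position cannot be treated as indifferent to such swaps. Nothing available bears on why this step occurs.

The compounds shown leave open how this position responds to a group other than chloro or bromo, such as fluoro, methoxy or an amine. They also leave open whether the chloro-to-bromo step repeats when the iodo on the other aromatic ring is replaced by trifluoromethyl.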